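Swapping Dimethylphenyl for Chlorophenyl on the Core

The source may hold more compounds than are shown below. What is called first, only, known or untested is meant among the compounds shown, and "the series" means these compounds.

Compound 2 `COc1ccc(CNC(=O)c2cc(-c3cc(C)cc(C)c3)cnc2-c2cccnc2)cc1OC` gives 462 nM in an assay on isolated protein for displacement of a labelled ligand from Orexin/Hypocretin receptor type 1 (Homo sapiens), read by scintillation counting, with a stated time of 60 min; a lower number here means a stronger inhibitor, a higher number a weaker inhibitor.
Compound 1 `Cc1cc(C)cc(-c2cnc(-c3cccnc3)c(C(=O)NCc3ccc(F)c(C)c3)c2)c1` gives 1110 nM in this assay.

Compound 2 holds the lowest of the two numbers; its nearest neighbour is compound 1, and the step of a 2.4-fold lower number from compound 1 to compound 2 (0.38 log units; beyond the scatter) lies beyond the scatter. Compound 3 `COc1ccc(CNC(=O)c2cc(-c3cccc(Cl)c3)cnc2-c2cccnc2)cc1OC` has not yet been measured. It differs from compound 2 by 3-chlorophenyl in place of 3,5-dimethylphenyl on an aromatic carbon. For the measured compounds named here, the only measured step, a 2.4-fold lower number from compound 1 to compound 2 (0.38 log units; beyond the scatter), concerns the group on the saturated chain carbon bound to the amide-type nitrogen, not the group on the aromatic carbon of the shared core, so it gives no direct guide to the present change. Going by the values given here, nothing measured so far shows how this part of the molecule responds to substitution. With that in mind, compound 3 is expected to land close to compound 2. The step of a 1.1-fold higher number from compound 2 to compound 3 (0.03 log units; within the scatter) is therefore expected to stay within the scatter, although the range must be kept wide. Compound 3 is estimated to give 500 nM in this assay, with a range from 200 nM to 1300 nM.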

Compound 3, inhibition constant: 747 nM
The estimate for compound 3 lay 1.5-fold (0.17 log units) below the measured number; measured number inside the range.
By their numbers in this assay, from the lowest: compounds 2, 3 and 1 (each within the scatter of the next, the first and the last beyond it).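

In this assay, for the compounds shown here, the step of a 1.6-fold higher number from compound 2 to compound 3 (0.21 log units; within the scatter) gives the first reading at this position, on the aromatic carbon para to the pyridin-3-yl group, and it lies within the scatter. Within this assay, therefore, 3-chlorophenyl and 3,5-dimethylphenyl cannot be told apart on this core, even though one ring carries a single chlorine and the other two methyl groups. This is a result for one pair of groups only, and no supporting information explains it or shows how the two compounds interact with the receptor.

The compounds shown leave open what each feature of the ring contributes, since chlorine and the two methyl groups differ at once; 3-methylphenyl, 3,5-dichlorophenyl and unsubstituted phenyl would separate the number of substituents from their identity. They also leave open whether this position accepts a much different group, such as a ring bearing a carboxylic acid or an aminomethyl group, or a longer chain in place of the aromatic ring, any of which could show a step beyond the scatter.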